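The source may report more compounds than this note shows. Statements on the series, on what has been measured and on what is new or still open speak of the compounds shown alone.

Working notes on the series. Within the data shown here, compound 3 `C=C1C(=O)OC[C@H]1CCOC(=O)Nc1ccc(CCCC)cc1` in an ADME assay on RAW264.7 cells (Mus musculus) for cytotoxicity, read by MTT assay, with a stated time of 18 h (on this read-out higher numbers stand for lower toxicity in this test and lower numbers for higher toxicity in this test), gives 15900 nM, the second highest of the three numbers so far; compound 2 `C=C1C(=O)OC[C@@H]1CCOC(=O)Nc1ccc(Br)cc1` gives 19800 nM and compound 1 `C=C1C(=O)OC[C@H]1CCOC(=O)Nc1ccc(OC)cc1` gives 12400 nM, and both of these gaps to compound 3 stay within the scatter. The only measured step, a 1.3-fold higher number from compound 1 to compound 3 (0.11 log units; within the scatter), is likewise within the scatter, so the series has not yet shown any change at this aromatic carbon that moves the number. Compound 4 `C=C1C(=O)OC[C@H]1CCOC(=O)Nc1ccc(Br)cc1` differs from compound 3 by bromo in place of butyl on an aromatic carbon. Among the measured compounds shown here, no measured step exchanges butyl for bromo; compound 2 also carries bromo on an aromatic carbon, with the other configuration at the ring stereocentre, and its value sits within the scatter of compound 3. Compound 4 is therefore expected near 18000 nM, with a range from 11000 nM to 30000 nM, the expected step of a 1.1-fold higher number from compound 3 to compound 4 (0.05 log units; within the scatter) not exceeding the scatter.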

Compound 4, half-maximal cytotoxic concentration: 8470 nM
Compound 4: middle estimate off by 2.1-fold (0.33 log units), on the high side; measured number below the stated range.
By their numbers in this assay, from the lowest: compounds 4, 1, 3 and 2 (each within the scatter of the next, the first and the last beyond it).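

In this assay, among these compounds, a 2.3-fold lower number from compound 2 to compound 4 (0.37 log units; beyond the scatter) is the first step beyond the scatter, though a modest one, and it arises because of what separates this pair: the fact that compounds 2 and 4 differ only in the configuration as drawn. At the aromatic carbon, a 1.9-fold lower number from compound 3 to compound 4 (0.27 log units; within the scatter) and a 1.5-fold lower number from compound 1 to compound 4 (0.17 log units; within the scatter) leave the exchange of substituents without a step beyond the scatter. So far, configuration at the ring stereocentre is the only change shown to move the number. Open, going by these compounds, is whether the configuration step recurs with methoxy or butyl on the aromatic carbon, and how an amine or a carboxylic acid there would read.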